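A Smaller Fused Ring on a Highly Soluble Series

The source may report more compounds than this note shows. Statements on the series, on what has been measured and on what is new or still open speak of the compounds shown alone.

In a physicochemical assay for solubility, in phosphate buffer, at pH 7.4 (on this read-out higher numbers stand for higher solubility and lower numbers for lower solubility), compound 1 (`CC(=O)N[C@@H]1CCC[C@H](C(=O)Nc2cc(-c3cnc(C)n3C(C)C)ccn2)C1`) gives 660000 nM as its reading. Compound 3 (`CC(=O)N[C@@H]1CCC[C@H](C(=O)Nc2cc(-c3cnc4n3CCCC4)c(Cl)cn2)C1`) gives 600000 nM on the same read-out, which lies within the usual scatter of the number for compound 1. Compound 2 (`CC(=O)N[C@@H]1CCC[C@H](C(=O)Nc2cc(-c3cnn4c3CCCC4)c(F)cn2)C1`) reads > 1000000 nM in this measurement, and that reading is a limit of the assay, not a number. Compound 3 and compound 1 therefore stand level.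

Compound 4 (`CC(=O)N[C@@H]1CCC[C@H](C(=O)Nc2cc(-c3cnc4n3CCC4)c(Cl)cn2)C1`) has not yet been measured. It differs from compound 3 in one group (a group of 8 heavy atoms (6 carbon, 2 nitrogen; one five-membered non-aromatic ring with 1 hetero atom, one five-membered aromatic ring with 2 hetero atoms) in place of a group of 9 heavy atoms (7 carbon, 2 nitrogen; one five-membered aromatic ring with 2 hetero atoms, one six-membered non-aromatic ring with 1 hetero atom), on an aromatic carbon) on an aromatic carbon, ortho to a chloro group and opposite the ring nitrogen. A five-membered non-aromatic ring takes the place of a six-membered non-aromatic ring. Going by the values given here, no two measured compounds differ in one place only, so the data give no direct guide to this change. In this assay no step beyond the scatter is expected, and the estimated move (a 1.1-fold higher number from compound 3 to compound 4 (0.03 log units; within the scatter)) is small. Compound 4 is estimated to give 650000 nM with an expected range from 300000 nM to 1000000 nM in this measurement.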

Compound 4, solubility: 490000 nM
For compound 4 the middle estimate is 1.3-fold (0.12 log units) above the measured one; the range from low to high includes it.
By their numbers in this assay, from the lowest: compounds 4, 3 and 1 (each within the scatter of the next). At a limit, above all of these: compound 2.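

In this assay, going by these compounds alone, the ring change gives a 1.2-fold lower number from compound 3 to compound 4 (0.09 log units; within the scatter), the first comparison between compounds that differ in one place only. With the chloro group kept, a five-membered non-aromatic ring can therefore take the place of a six-membered non-aromatic ring at this aromatic carbon, opposite the ring nitrogen, with no change in the reading beyond the usual scatter. This step rests on two true numbers, whereas compound 2 reads at a limit of the assay: the limit of > 1000000 nM in this assay, at which 1 of the 4 values shown sits.

From the compounds shown here alone, whether the same ring change would read alike with a fluoro group in place of the chloro group remains open. So does the outcome of a seven-membered non-aromatic ring at this position, or of an amine or a carboxylic acid carried on the non-aromatic ring.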